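Furan-2-yl for thiophen-3-yl on the shared core

The source may report more compounds than this note shows. Statements on the series, on what has been measured and on what is new or still open speak of the compounds shown alone.

Compound 1 `Nc1nc(N)c2c(-c3ccsc3)cn([C@@H]3O[C@H](CO)[C@@H](O)[C@H]3O)c2n1` carries thiophen-3-yl on the shared core. In a functional assay on A549 cells (Homo sapiens), read by MTT assay, with a stated time of 72 h (a higher number here means a weaker inhibitor, a lower number a stronger inhibitor), compound 1 gives only a limit, > 100000 nM. Compound 2 `COc1nc(N)nc2c1c(-c1ccsc1)cn2[C@@H]1O[C@H](CO)[C@@H](O)[C@H]1O` has methoxy in place of amino on an aromatic carbon; in this assay compound 2 likewise gives a limit, > 100000 nM. Compound 3 `Cc1ncnc2c1c(-c1ccsc1)cn2[C@@H]1O[C@H](CO)[C@@H](O)[C@H]1O` in this assay also gives a limit, > 20000 nM. The step that the two limits leave unreadable from compound 1 to compound 2 has no readable size because the limit of > 100000 nM in this assay, at which 2 of the 3 values shown sit, covers both of its ends. Compound 1 therefore stands nowhere readable on the numbers shown: every value is a limit, the limit of > 100000 nM in this assay, at which 2 of the 3 values shown sit, and (the limit of > 20000 nM in this assay, at which 1 of the 3 values shown sits), and no measured step carries a size.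

Compound 4 `Nc1nc(N)c2c(-c3ccco3)cn([C@@H]3O[C@H](CO)[C@@H](O)[C@H]3O)c2n1` differs from compound 1 by furan-2-yl in place of thiophen-3-yl on an aromatic carbon. Among the measured compounds shown here, no measured step touches the group on that ring carbon, and the single measured step, amino to methoxy, cannot be sized either. All three values shown sit at limits, so nothing within the series suggests a readable step in this assay for compound 4. The estimate for compound 4 is 100000 nM, expected between 30000 nM and 300000 nM, and most probably reported again as a limit. The expected step is a number no higher from compound 1 to compound 4 (the limit leaves the size open), meaning none beyond the scatter.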

Compound 4, half-maximal inhibitory concentration: > 20000 nM
Compound 4 ended at the assay's limit (the forecaster's own chance of this, stated with the estimate: 85%); the middle value does not contradict the limit.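

In this assay compound 4 gives only a limit, > 20000 nM. Among the compounds shown here, compound 1 also gives only a limit, so no step between compound 1 and compound 4 can be read. Left open is how far any compound shown lies past its limit, and whether furan-2-yl and thiophen-3-yl on the shared core differ at all in this assay.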